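Notes on the aryl exchange from compound 3

This account rests on a few compounds, and the source may have more. Where it says the series, first, only, none or still open, it means among the compounds named here.

Values in a functional assay on M21 cells (Homo sapiens) for antiproliferative activity, read by sulforhodamine B assay, with a stated time of 48 h; on this read-out lower numbers stand for stronger inhibition and higher numbers for weaker inhibition:
- compound 1 `CCCN1CCN(c2ccc(S(=O)(=O)Oc3cccc(F)c3)cc2)C1=O` gives 12000 nM
- compound 2 `CCCN1CCN(c2ccc(S(=O)(=O)Oc3ccc(OC)cc3)cc2)C1=O` gives 23000 nM
- compound 3 `CCCCN1CCN(c2ccc(S(=O)(=O)Oc3cccc(F)c3)cc2)C1=O` gives > 100000 nM (a limit)

The value of compound 3 is a limit of this assay and not a number, as noted in the limit of > 100000 nM in this assay, at which 1 of the 3 values shown sits. Compound 4 `CCCCN1CCN(c2ccc(S(=O)(=O)Oc3ccc(OC)cc3)cc2)C1=O` differs from compound 3 in one place: 4-methoxyphenyl in place of 3-fluorophenyl on an oxygen. The same exchange was measured as a 1.9-fold higher number from compound 1 to compound 2 (0.28 log units; within the scatter). The other step, an at least 8.3-fold higher number from compound 1 to compound 3 (0.92 log units; beyond the scatter), is a different change that compound 3 already carries. On the strength of a 1.9-fold higher number from compound 1 to compound 2 (0.28 log units; within the scatter), no step beyond the scatter is expected in this assay. The expected change is a number no higher from compound 3 to compound 4 (the limit leaves the size open). The estimate for compound 4 is 100000 nM, with an expected range of 30000 nM to 250000 nM.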

Compound 4, half-maximal inhibitory concentration: > 100000 nM
Compound 4: no number, only a limit; the forecaster's own chance of this, stated with the estimate: 60%; the middle value sits exactly at the limit.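

In this assay compound 4 gives > 100000 nM, which is a limit and not a number. The step from compound 3 to compound 4 cannot be read, since both values are limits. The methyl on the saturated chain carbon now also reads with 4-methoxyphenyl, as an at least 4.3-fold higher number from compound 2 to compound 4 (0.63 log units; beyond the scatter), so the rise in the number is not confined to the 3-fluorophenyl compounds: the same change on two cores in this assay, an at least 8.3-fold higher number (0.92 log units; beyond the scatter) from compound 1 to compound 3 and an at least 4.3-fold higher number (0.63 log units; beyond the scatter) from compound 2 to compound 4; the limit leaves it open whether they differ

As far as these compounds go, the true size of this step on either aryl group stays open. So does the effect of an ethyl chain at the same nitrogen, or of an amine at the end of the chain, in this assay.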